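Swapping Chloro for Bromo on the Shared Core

The source may report more compounds than this note shows. Statements on the series, on what has been measured and on what is new or still open speak of the compounds shown alone.

Measured compounds and their values:
- Compound 1, `Cc1ccc([C@H]2CC(c3ccccc3)=NN2c2ncc(Br)cn2)cc1`: 71%
- Compound 2, `Clc1ccc([C@H]2CC(c3ccccc3)=NN2c2ncc(Br)cn2)cc1`: 71%

Both measured compounds were tested in a functional assay on the whole organism (strain Wistar albino) for inhibition, with Rattus norvegicus as the target, read by paw edema, with stated times of 30 min and 1.5 h, at a dose of 20 mg/kg; on this read-out lower numbers stand for less inhibition and higher numbers for more inhibition at the one dose given (going by the name of the read-out). Compound 1 gives 71%, and compound 2 gives 71%. Compound 2 therefore stands level with compound 1 at the digits shown; the one measured step, no change at the digits printed from compound 1 to compound 2 (within the scatter), put chloro in place of methyl on an aromatic carbon and left the read-out unchanged within the scatter.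

The next compound, compound 3, is `Brc1ccc([C@H]2CC(c3ccccc3)=NN2c2ncc(Br)cn2)cc1`. It differs from compound 2 by bromo in place of chloro on an aromatic carbon.

Among the measured compounds shown here, only one measured step bears on this change, the swap of one small group for another at the same aromatic carbon, and it moved nothing. For the measured compounds named here, the data hold no example of a bromo group at this place, so the expectation rests on that single step alone. The expected step is no change at the digits printed from compound 2 to compound 3 (within the scatter), that is, no movement beyond the scatter. For compound 3 the estimated value in this assay is 71%, with an expected range from 58% to 82%.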

Compound 3, a percentage reported as inhibition, in the whole organism at one dose (the size of the read-out at that dose, not a potency): 74%
Compound 3: the middle estimate sits 3 percentage points below what was measured, and the stated range covers the measured number.
By their numbers in this assay, from the lowest: compounds 1, 2 and 3 (each within the scatter of the next).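

Bromo now joins methyl and chloro at this place on the aromatic ring, para to a large group, and in this assay the new compound reads like the other two. Bromo in place of chloro gives a number 3 percentage points higher from compound 2 to compound 3 (within the scatter) and bromo in place of methyl gives a number 3 percentage points higher from compound 1 to compound 3 (within the scatter) so, at this one dose, the read-out does not separate these three groups at this position, and 4-bromophenyl serves as well as 4-chlorophenyl. No supporting measurement is available to explain why these three groups read alike.

On these data alone, whether this position accepts groups of a quite different kind stays open, and an amine, a carboxylic acid or a longer chain placed here would put that to the test. As far as these compounds go, the result in this assay also gives the size of the effect at a single dose rather than a potency, so whether these compounds would separate at other doses remains unknown.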